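Triazole-linked pyrazole amides: benzyl methoxy pattern

A few compounds are considered here, and "the series" means these few. Any claim that something is new, unique, unknown or untested is made for them only; others in the source may bear on it.

Measured so far:
compound 1 `COc1cc(Cn2cc(CNC(=O)c3cn(-c4ccccc4)nc3-c3ccccc3)nn2)cc(OC)c1` — 12200 nM
compound 2 `COc1ccc(Cn2cc(CNC(=O)c3cn(-c4ccccc4)nc3-c3ccc(F)cc3)nn2)cc1` — 870 nM

In a functional assay on HeLa cells (Homo sapiens) for antiproliferative activity, read by sulforhodamine B assay, with a stated time of 48 h (a lower number here means a stronger inhibitor of growth, a higher number a weaker inhibitor of growth), compound 2 gives the lowest of the two numbers; compound 1 sits at a higher number, beyond the scatter. Compound 1 and compound 2 differ in two places at once, so their two values cannot be split into separate steps.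

Compound 3 `COc1cc(Cn2cc(CNC(=O)c3cn(-c4ccccc4)nc3-c3ccc(F)cc3)nn2)cc(OC)c1` is not yet measured. It keeps the fluorophenyl of compound 2 and changes the benzyl: 3,5-dimethoxyphenyl in place of 4-methoxyphenyl on a saturated chain carbon bound to an aromatic nitrogen. The same 3,5-dimethoxybenzyl is carried by compound 1, where this assay gave 12200 nM; compound 2, with the 4-methoxybenzyl, gave 870 nM. The step from compound 2 to compound 3 is expected to run toward a weaker inhibitor, by about a 3.7-fold higher number from compound 2 to compound 3 (0.57 log units; beyond the scatter), with wide uncertainty since the two measured compounds differ in two places. Compound 3 is therefore estimated at 3200 nM, in the range 900 nM to 12000 nM.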

Compound 3, concentration for 50% growth inhibition: 360 nM
For compound 3 the middle estimate is 8.9-fold (0.95 log units) above the measured one; measured number outside the range, below it.
By their numbers in this assay, from the lowest: compound 3; then compound 2; then compound 1.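

In this assay the benzyl change on the fluorophenyl background is a modest gain (a 2.4-fold lower number from compound 2 to compound 3 (0.38 log units; beyond the scatter)), so 3,5-dimethoxyphenyl on a saturated chain carbon bound to an aromatic nitrogen does not by itself carry the weak value of compound 1. With the 3,5-dimethoxybenzyl held fixed, fluoro in place of hydrogen on an aromatic carbon gives the large step of the series (a 34-fold lower number from compound 1 to compound 3 (1.53 log units; beyond the scatter)), so the aryl fluorine counts for far more here than the benzyl methoxy pattern. No measured property bears on either step.

On these data alone, whether the fluoro step is as large with the 4-methoxybenzyl remains open. Also open, as far as these compounds go, is how chloro in place of that fluoro, or a benzyl carrying a hydroxyl or a dimethylamino group, would read in this assay on this core.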